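The source may hold more compounds than are shown below. What is called first, only, known or untested is meant among the compounds shown, and "the series" means these compounds.

In an assay on HEK293 cells for positive allosteric modulation of metabotropic glutamate receptor 2 (Rattus norvegicus), read by thallium flux (on this read-out higher numbers stand for an effect only at larger amounts of compound and lower numbers for an effect already at smaller amounts), compound 2 `CC(C)CN1Cc2cc(OCc3cccc(-c4ccc(Cl)c(C(=O)O)c4)c3)ccc2C1=O` gives 100 nM. Within the data shown here, the only other number comes from compound 1 `O=C(O)c1cc(-c2cccc(COc3ccc4c(c3)CN(CC3CC3)C4=O)c2)ccc1Cl`, which in this assay gives 80 nM; the two values lie within the usual scatter of each other, so nothing separates them with confidence. Among the measured compounds shown here, the single measured step, a 1.3-fold higher number from compound 1 to compound 2 (0.10 log units; within the scatter), exchanged one small saturated group for another on the carbon attached to the ring nitrogen of the amide and left the read-out essentially unchanged.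

Compound 3 `CC(C)CCN1Cc2cc(OCc3cccc(-c4ccc(Cl)c(C(=O)O)c4)c3)ccc2C1=O` takes this same position one step further: isobutyl in place of isopropyl on a saturated chain carbon bound to an amide-type nitrogen in a ring. The chain on that carbon grows by one carbon while nothing else in the molecule changes. For the measured compounds named here, the only step that bears on this, a 1.3-fold higher number from compound 1 to compound 2 (0.10 log units; within the scatter), shows that modest changes of the saturated group at this place stayed inside the scatter, so for compound 3 a step of about a 1.2-fold higher number from compound 2 to compound 3 (0.08 log units; within the scatter) is expected, that is, no shift beyond the scatter in either direction. The estimate for compound 3 is therefore 120 nM, with a range from 50 nM to 300 nM.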

Compound 3, half-maximal effective concentration: 60 nM
Beside the measured number, compound 3's estimate is 2.0-fold (0.30 log units) above it; measured number inside the range.
By their numbers in this assay, from the lowest: compounds 3, 1 and 2 (each within the scatter of the next).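

Read in this assay, the added carbon, isobutyl in place of isopropyl, gives a 1.7-fold lower number from compound 2 to compound 3 (0.22 log units; within the scatter), so this larger group still cannot be told apart from the smaller one. The comparison with the ring-shaped group gives a 1.3-fold lower number from compound 1 to compound 3 (0.12 log units; within the scatter), which means that the earlier finding, resting on a single pair, now holds for all three groups at this place: cyclopropyl, isopropyl and isobutyl are within the scatter of each other, so the read-out does not respond measurably to these differences in group size and shape. No accompanying measurement bears on this result.

The compounds shown leave open how far this flat picture extends, for instance whether a longer chain such as hexyl or a larger group such as benzyl would still stay within the scatter of these three. Equally open, going by these compounds, is what a chain carrying an amine, a hydroxyl or a carboxylic acid would do at this place, since all three groups here are plain carbon groups with no hydrogen-bond donors or acceptors.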